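The source may hold more compounds than are shown below. What is called first, only, known or untested is meant among the compounds shown, and "the series" means these compounds.

Going by the values given here, compound 3 `c1ccc(Cn2nnc3c(NC4CCCC4)nc(-c4ccccc4)nc32)cc1` gives 11000000 nM in an assay on isolated protein for binding affinity to adenosine receptor A1 (Bos taurus) (a lower number here means a stronger inhibitor, a higher number a weaker inhibitor), the highest of the three numbers measured so far; compound 1 `Fc1ccccc1Cn1nnc2c(NC3CCCCC3)nc(-c3ccccc3)nc21` gives 1150000 nM and compound 2 `OC1CCC(Nc2nc(-c3ccccc3)nc3c2nnn3Cc2ccccc2F)CC1` gives 1850000 nM, both lower by more than the scatter. The step to compound 4 `O[C@H]1CCCC[C@@H]1Nc1nc(-c2ccccc2)nc2c1nnn2Cc1ccccc1` is 2-hydroxycyclohexyl in place of cyclopentyl on a nitrogen on an aromatic ring. Among the compounds with values here, the only measured step that bears on it is a 1.6-fold higher number from compound 1 to compound 2 (0.21 log units; within the scatter), which adds a hydroxy on a saturated ring carbon and stays within the scatter; the change from a five-membered to a six-membered ring has no single-change comparison, since compound 3 and compound 1 differ in two places. On this basis a step of a 2.8-fold lower number from compound 3 to compound 4 (0.44 log units; beyond the scatter) is expected. Compound 4 is therefore estimated at 4000000 nM, with a range from 1000000 nM to 15000000 nM.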

Compound 4, inhibition constant: 10300000 nM
Compound 4: middle estimate off by 2.6-fold (0.41 log units), on the low side; the measured number falls inside the stated range.
By their numbers in this assay, from the lowest: compounds 1 and 2 (each within the scatter of the next); then compounds 4 and 3 (each within the scatter of the next).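

In this assay, 2-hydroxycyclohexyl in place of cyclopentyl on a nitrogen on an aromatic ring gives a 1.1-fold lower number from compound 3 to compound 4 (0.03 log units; within the scatter). The earlier step showed only a hydroxy added to a saturated ring, whereas this one shows that a change of ring and a hydroxy together, with two defined stereocentres, also stays within the scatter at this position. Nothing available accounts for this result. The compounds shown leave open whether the other stereoisomers of 2-hydroxycyclohexyl would give a different number, and whether an amine or a carboxylic acid on the ring, or an open butyl chain in its place, would shift the number at this position.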